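The source may hold more compounds than are shown below. What is called first, only, known or untested is meant among the compounds shown, and "the series" means these compounds.

Of the compounds shown here, two of the shared core carry numbers so far. Compound 1 `CCOC(=O)C1=C(C)NC(=O)NC1c1ccc(O)c(O)c1` bears two hydroxy groups on its aryl ring and a carbonyl in the core; in a functional assay on HT-29 cells (Homo sapiens) for inhibition, read by sulforhodamine B assay, with a stated time of 48 h (on this read-out lower numbers stand for stronger inhibition of growth and higher numbers for weaker inhibition of growth), compound 1 gives 37.8 ug/mL. Compound 2 `CCOC(=O)C1=C(C)NC(=S)NC1c1ccc(SC)cc1` bears a methylsulfanyl group on its aryl ring and a thiocarbonyl in the core; in this assay compound 2 gives 17.2 ug/mL. Compound 2 therefore holds the lower of the two numbers, and its gap to compound 1 lies beyond the usual scatter. Compound 1 and compound 2 differ in more than one place, so no single step can be read from the pair.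

Compound 3 `CCCc1ccc(C2NC(=S)NC(C)=C2C(=O)OCC)cc1` is not yet measured. Against compound 2 it differs in one place: propyl in place of methylsulfanyl on an aromatic carbon. Within the data shown here, no measured pair isolates a change of this kind, so neither a direction nor a size can be read from the numbers in hand. The step of a 1.2-fold higher number from compound 2 to compound 3 (0.07 log units; within the scatter) is expected to stay within the scatter, with no clear direction. Compound 3 is accordingly estimated at 20 ug/mL in this assay, within a range from 8 ug/mL to 50 ug/mL.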

Compound 3, concentration for 50% growth inhibition: 50.4 ug/mL
The estimate for compound 3 lay 2.5-fold (0.40 log units) below the measured number, and the stated range ends below it.
By their numbers in this assay, from the lowest: compound 2; then compounds 1 and 3 (each within the scatter of the next).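

Read in this assay and made on an aromatic carbon of a six-membered aromatic ring of carbon only, para to a large group, propyl in place of methylsulfanyl gives a 2.9-fold higher number from compound 2 to compound 3 (0.47 log units; beyond the scatter) and so supplies the first single-place step of the series. The step is modest but lies beyond the scatter, which shows that the group at this position can shift the number, and within this pair methylsulfanyl goes with the stronger inhibition of growth. No supporting data on hand bear on the origin of this step.

The compounds shown leave open whether the step follows the sulfur of methylsulfanyl or the chain of propyl, a question that methoxy, ethyl or a longer chain such as butyl at the same position would address, and an amine or a carboxylic acid there would test a further kind of group. Also open, as far as these compounds go, is the separate effect of carbonyl against thiocarbonyl in the shared core, and of the two hydroxy groups of compound 1, since that compound differs from the others in more than one place.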